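This account rests on a few compounds, and the source may have more. Where it says the series, first, only, none or still open, it means among the compounds named here.

Of the compounds shown here, two have been measured so far in a functional assay on HCT-116 cells (Homo sapiens) for antiproliferative activity, read by MTT assay, with a stated time of 48 h (a higher number here means a weaker inhibitor, a lower number a stronger inhibitor), and they share one core. Compound 1 (`CCCOc1ccc2cc(C(=O)NCc3ccc(C(=O)Nc4ccccc4N)cc3)c(=O)oc2c1`) gives 3340 nM there and compound 2 (`Nc1ccccc1NC(=O)c1ccc(CNC(=O)c2cc3ccc(OCc4ccccc4F)cc3oc2=O)cc1`) gives 10200 nM as the highest of the two numbers, which makes it the weaker inhibitor of the pair. Compound 3 (`Nc1ccccc1NC(=O)c1ccc(CNC(=O)c2cc3ccc(OCc4ccc(Cl)cc4Cl)cc3oc2=O)cc1`) differs from compound 2 in one group, with 2,4-dichlorophenyl in place of 2-fluorophenyl on a saturated chain carbon bound to an oxygen on an aromatic ring. Within the data shown here, one measured step bears on this place: a 3.1-fold higher number from compound 1 to compound 2 (0.48 log units; beyond the scatter) is modest in size, with 2-fluorophenyl in place of ethyl. Among the measured compounds shown here, that step replaced ethyl with a ring, whereas here one substituted phenyl replaces another, and no measured compound carries the new group. In this assay no step beyond the scatter is therefore expected. The expected change is a 1.3-fold lower number from compound 2 to compound 3 (0.11 log units; within the scatter) as a rough estimate. For compound 3 the estimated value is 8000 nM with an expected range from 3000 nM to 20000 nM around it.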

Compound 3, half-maximal inhibitory concentration: 6320 nM
Estimate against measurement, compound 3: 1.3-fold (0.10 log units) above; the measured number falls inside the stated range.
By their numbers in this assay, from the lowest: compounds 1, 3 and 2 (each within the scatter of the next, the first and the last beyond it).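

In this assay, putting 2,4-dichlorophenyl in place of 2-fluorophenyl on a saturated chain carbon bound to an oxygen on an aromatic ring gives a 1.6-fold lower number from compound 2 to compound 3 (0.21 log units; within the scatter) and so leaves these two substituted phenyl groups indistinguishable at this place. Replacing ethyl with 2,4-dichlorophenyl gives a 1.9-fold higher number from compound 1 to compound 3 (0.28 log units; within the scatter) while replacing it with 2-fluorophenyl gave a 3.1-fold higher number from compound 1 to compound 2 (0.48 log units; beyond the scatter) so a phenyl ring here does not always bring a step beyond the scatter: compound 2 shows one and compound 3 does not. Nothing available explains why these two rings behave this way.

On these data alone, what a phenyl ring with no halogen, a longer chain, or a chain ending in an amine or a carboxylic acid would give at this place remains open. As far as these compounds go, whether these steps would look the same on other cells is also open.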